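The source may report more compounds than this note shows. Statements on the series, on what has been measured and on what is new or still open speak of the compounds shown alone.

Three compounds built on a shared core have so far been examined in a functional assay on K562 cells (Homo sapiens) for inhibition, read by thymidine incorporation, with a stated time of 48 h, tested at 10 ug/mL; a lower number here means less inhibition, a higher number more inhibition at the concentration tested (going by the name of the read-out). Compound 1, `CC(C)=CC#Cc1[nH]cnc2ncnc1-2`, gives 30%. Compound 2, `OC[C@H]1OC(n2cnc3c(/C=C/c4ccccc4)ncnc32)[C@H](O)[C@@H]1O`, gives 79%. Compound 3, `COc1ccc(/C=C/c2ncnc3c2ncn3C2CCOCC2)cc1`, gives 58%, which places it second highest of the three: compound 2 stands above it by a margin beyond the scatter, while compound 1 lies below it, also beyond the scatter.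

Compound 4, `C(=C/c1ncnc2c1ncn2C1CCOCC1)\c1cccs1`, has not yet been measured in this assay. It differs from compound 3 in a single place: thiophen-2-yl in place of 4-methoxyphenyl on a double-bonded chain carbon bound to a double-bonded chain carbon. Among the measured compounds shown here, no pair of measured compounds differs in only this part of the molecule, so the data give no direct indication of how large such a step might be. The step of a number 8 percentage points lower from compound 3 to compound 4 (within the scatter) is therefore expected to be small, close to or within the usual scatter, with a slight lean toward lower inhibition. For compound 4 in this assay the estimate is 50%, with a range from 25% to 75%.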

Compound 4, a percentage reported as inhibition, at one concentration (the size of the read-out at that concentration, not a potency): 65%
Beside the measured number, compound 4's estimate is 15 percentage points below it; the measured number falls inside the stated range.
By their numbers in this assay, from the lowest: compound 1; then compounds 3 and 4 (each within the scatter of the next); then compound 2.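

In this assay, putting thiophen-2-yl in place of 4-methoxyphenyl on a double-bonded chain carbon bound to a double-bonded chain carbon gives a number 7 percentage points higher from compound 3 to compound 4 (within the scatter), the first step measured at this place. For this pair, a five-membered aromatic ring with a sulfur atom and a six-membered aromatic ring of carbon only, bearing its methoxy group, cannot be told apart by this read-out, even though the entering group has fewer heavy atoms. Nothing available explains why the two groups read alike.

From the compounds shown here alone, what a pyridine ring or a carboxylic acid would give at this same place remains open. Going by these compounds, it is also open whether this step would stay as small with a different group on the rest of the shared core.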